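Trimethoxyphenyl on the pyrrole nitrogen: an estimate

The compounds below may be only part of what the source reports. "The series", "measured", "known", "first", "only" and "open" are said of these compounds alone.

Compounds measured in a functional assay on MCF7 cells (Homo sapiens) for cytotoxicity, read by MTT assay, with a stated time of 96 h; on this read-out lower numbers stand for stronger inhibition and higher numbers for weaker inhibition:
- compound 1 `COc1cc(C(=O)c2cn(-c3ccccc3C)cc2-c2ccccc2)cc(OC)c1OC`: 2200 nM
- compound 2 `COc1cc(C(=O)c2cn(-c3ccccc3N)cc2-c2ccccc2)cc(OC)c1OC`: 3800 nM
- compound 3 `COc1cc(C(=O)c2cn(-c3cccc(Cl)c3)cc2-c2ccccc2)cc(OC)c1OC`: 150 nM

Compound 1 stands second highest of the three numbers in this assay. Its nearest neighbour is compound 2, reached by the step of a 1.7-fold higher number from compound 1 to compound 2 (0.24 log units; within the scatter), a step that stays within the scatter. The furthest is compound 3, reached by the step of a 15-fold lower number from compound 1 to compound 3 (1.17 log units; beyond the scatter), a large step beyond the scatter.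

Compound 4 `COc1cc(C(=O)c2cn(-c3cc(OC)c(OC)c(OC)c3)cc2-c2ccccc2)cc(OC)c1OC` is not yet measured. It differs from compound 1 in one place: 3,4,5-trimethoxyphenyl in place of 2-methylphenyl on an aromatic nitrogen. Going by the values given here, no measured step exchanges the group on that aromatic nitrogen for a 3,4,5-trimethoxyphenyl, so the bearing of the data is indirect. The step of a 15-fold lower number from compound 1 to compound 3 (1.17 log units; beyond the scatter) shows that replacing the 2-methylphenyl on this nitrogen can lower the number strongly, while a 1.7-fold higher number from compound 1 to compound 2 (0.24 log units; within the scatter) shows that a small change on that same ring can leave the number unchanged. A step in the lowering direction is therefore expected, of moderate size and with wide uncertainty: a 3.1-fold lower number from compound 1 to compound 4 (0.50 log units; beyond the scatter) is estimated. Compound 4 is expected to give about 700 nM in this assay, with a range from 120 nM to 4000 nM.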

Compound 4, half-maximal inhibitory concentration: > 5000 nM
Compound 4: no number, only a limit; the forecaster's own chance of this, stated with the estimate: 5%; middle value at least 7.1-fold (0.85 log units) away from the limit.
By their numbers in this assay, from the lowest: compound 3; then compounds 1 and 2 (each within the scatter of the next). At a limit, above all of these: compound 4.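

In this assay compound 4 gives no number, only a limit of the assay: the limit of > 5000 nM in this assay, at which 1 of the 4 values shown sits.

Placing 3,4,5-trimethoxyphenyl on the aromatic nitrogen gives an at least 2.2-fold higher number from compound 1 to compound 4 (0.35 log units; beyond the scatter) and an at least 33-fold higher number from compound 3 to compound 4 (1.52 log units; beyond the scatter) as well as an at least 1.3-fold higher number from compound 2 to compound 4 (0.11 log units; that floor lies within the scatter). The last of these is only a floor that lies within the scatter, so it cannot be read as a separation. The earlier compounds had shown a step beyond the scatter at this position only in the lowering direction, with compound 3, whereas this exchange moves the number the other way.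

From the compounds shown here alone, how far compound 4 lies past its limit remains open. So does whether a phenyl carrying a single methoxy group, or a hydroxyl in place of methoxy, would behave like 3-chlorophenyl or like 3,4,5-trimethoxyphenyl on this nitrogen.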